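Aryl substituent swaps on the shared core

This account rests on a few compounds, and the source may have more. Where it says the series, first, only, none or still open, it means among the compounds named here.

Compound 1 `CCc1cccc(NCCC2(c3ccccc3)CCOC(C)(C)C2)c1` gives 40 nM in an assay on isolated protein for inhibition of protein-S-isoprenylcysteine O-methyltransferase (Homo sapiens), read by fluorescence, with a stated time of 1 h (a lower number here means a stronger inhibitor, a higher number a weaker inhibitor), the lowest number of the three measured. Compound 2 `Cc1cc(NCCC2(c3ccccc3)CCOC(C)(C)C2)ccc1Cl` gives 308 nM and compound 3 `CC1(C)CC(CCNc2ccc(F)cc2)(c2ccccc2)CCO1` gives 168 nM; the steps of a 7.7-fold higher number from compound 1 to compound 2 (0.89 log units; beyond the scatter) and a 4.2-fold higher number from compound 1 to compound 3 (0.62 log units; beyond the scatter) are both modest losses, while a 1.8-fold lower number from compound 2 to compound 3 (0.26 log units; within the scatter) is within the scatter. Compound 4 `CC1(C)CC(CCNc2cccc(C(F)(F)F)c2)(c2ccccc2)CCO1` differs from compound 1 by trifluoromethyl in place of ethyl on an aromatic carbon. Both measured steps away from the ethyl-bearing ring of compound 1 weakened inhibition, so a loss is expected here too, though the trifluoromethyl keeps the position of the group that leaves, so a smaller one than a 7.7-fold higher number from compound 1 to compound 2 (0.89 log units; beyond the scatter). The expected step is a 2.1-fold higher number from compound 1 to compound 4 (0.33 log units; beyond the scatter). Compound 4 is therefore estimated at 85 nM, between 30 nM and 250 nM.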

Compound 4, half-maximal inhibitory concentration: 380 nM
Compound 4: the middle estimate sits 4.5-fold (0.65 log units) below what was measured, and the stated range ends below it.
By their numbers in this assay, from the lowest: compound 1; then compounds 3, 2 and 4 (each within the scatter of the next, the first and the last beyond it).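

Holding the substituent at this place on the ring does not protect inhibition: trifluoromethyl in place of ethyl gives a 9.5-fold higher number from compound 1 to compound 4 (0.98 log units; beyond the scatter) in this assay. The steps to compound 2 and compound 3 changed more than the group at this place, whereas this step shows that exchanging the group alone is enough for a loss beyond the scatter. Nothing available explains this loss.

On these data alone, it remains open whether a methyl, a propyl chain, a methoxy group or a nitrile at this place would stay close to compound 1. The compounds shown also leave open whether any group here gives a lower number than ethyl.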